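Working notes: aryl variation on the ring nitrogen of compound 1

The compounds below may be only part of what the source reports. "The series", "measured", "known", "first", "only" and "open" are said of these compounds alone.

Measured so far:
compound 1 `COc1ccc(Br)cc1Nc1cc(NC(=O)Nc2c(Cl)cccc2Cl)ncn1` — 53.3%
compound 2 `COc1cc(NC(=O)Nc2cc(Nc3cc(Br)ccc3OC)ncn2)cc(OC)c1` — 23.1%
compound 3 `COc1ccc(OC)c(Nc2cc(NC(=O)Nc3c(Cl)cccc3Cl)ncn2)c1` — 93.1%

In a functional assay on NCI-H1581 cells (Homo sapiens) for inhibition, read by MTT assay, with a stated time of 48 h, tested at 10 uM (on this read-out lower numbers stand for less inhibition and higher numbers for more inhibition at the one concentration tested (going by the name of the read-out)), compound 1 gives 53.3%, the second highest of the three numbers; compound 2 sits lower by a number 30.2 percentage points lower from compound 1 to compound 2 (beyond the scatter) and compound 3 higher by a number 39.8 percentage points higher from compound 1 to compound 3 (beyond the scatter), both beyond the scatter. The step to compound 2 changes the group on the amide-type nitrogen and says nothing about the aryl on the ring nitrogen. The step to compound 3 does: it changes that aryl, and the gain is large.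

Compound 4 `COc1ccc(Nc2cc(NC(=O)Nc3c(Cl)cccc3Cl)ncn2)cc1C` differs from compound 1 in one place: 4-methoxy-3-methylphenyl in place of 5-bromo-2-methoxyphenyl on a nitrogen on an aromatic ring. The bromo leaves, as it does on the way to compound 3, but a methyl enters and the methoxy sits differently, so the step to compound 3 bears on it only in part. A rise beyond the scatter is expected, smaller than a number 39.8 percentage points higher from compound 1 to compound 3 (beyond the scatter).

For compound 4 a value of 68% is estimated, in the range 45% to 90%. This estimate means an expected step of a number 14.7 percentage points higher from compound 1 to compound 4 (beyond the scatter).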

Compound 4, a percentage reported as inhibition, at one concentration (the size of the read-out at that concentration, not a potency): 45.1%
The estimate for compound 4 lay 22.9 percentage points above the measured number; low and high end bracket the measured number.
By their numbers in this assay, from the lowest: compound 2; then compounds 4 and 1 (each within the scatter of the next); then compound 3.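

In this assay the exchange of 5-bromo-2-methoxyphenyl for 4-methoxy-3-methylphenyl on the ring nitrogen gives a number 8.2 percentage points lower from compound 1 to compound 4 (within the scatter) and so leaves no readable change, although the whole substitution pattern of the aryl differs. Removing the bromo therefore does not bring a gain in every case: the large rise given by a number 39.8 percentage points higher from compound 1 to compound 3 (beyond the scatter) does not recur in this aryl, and this position does not treat all bromo-free aryls alike, with compound 4 at 45.1% and compound 3 at 93.1% in the printed values. No measurement on hand bears on why these two bromo-free aryls part ways.

Still open, on these data alone, is whether the gain in compound 3 belongs to the methoxy that replaces the bromo specifically, or would also appear with another group on that aromatic carbon, such as an amine, a hydroxyl or a morpholine ring. As far as these compounds go, it is equally open whether the 2,6-dichlorophenyl on the amide-type nitrogen, retained in compounds 1, 3 and 4, is needed for the aryl differences to appear at all.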